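This account rests on a few compounds, and the source may have more. Where it says the series, first, only, none or still open, it means among the compounds named here.

Among the measured compounds shown here, in an ADME assay on HEK293 cells (Homo sapiens) for cytotoxicity, read by reporter gene assay and resazurin assay, with a stated time of 48 h (on this read-out higher numbers stand for lower toxicity in this test and lower numbers for higher toxicity in this test), compound 1 (`O=C(Nc1cccc(Cl)c1)c1ccccc1O`) gives 37000 nM, the only actual number so far. Compound 2 (`O=C(Nc1ccccc1)c1cc(Br)cc(Br)c1`) gives > 100000 nM, which is a limit and not a number. Compound 3 (`COc1c(Br)cc(Br)cc1C(=O)Nc1ccc(Sc2nc3ccccc3s2)c(Cl)c1`), which carries a methoxy, gives > 100000 nM, also a limit. The series thus shows (the limit of > 100000 nM in this assay, at which 2 of the 3 values shown sit).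

Compound 4 (`COc1ccccc1C(=O)Nc1cccc(Cl)c1`) alters compound 1 at one place: methyl in place of hydrogen on an oxygen on an aromatic ring, hydroxy to methoxy. For the measured compounds named here, no measured pair isolates this change. A modest rise in this assay is expected, resting only on compound 3 at > 100000 nM, a limit reached on a much different structure. The expected step of a 1.6-fold higher number from compound 1 to compound 4 (0.21 log units; within the scatter) is therefore small and uncertain. For compound 4 the estimate is 60000 nM, with an expected range of 25000 nM to 100000 nM.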

Compound 4, half-maximal cytotoxic concentration: > 100000 nM
Compound 4 gave a limit, no number; the forecaster's own chance of this, stated with the estimate: 30%; middle value at least 1.6-fold (0.22 log units) from the limit.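

In this assay, among the compounds shown here, the change from hydroxy to methoxy gives an at least 2.7-fold higher number from compound 1 to compound 4 (0.43 log units; beyond the scatter) in the only measured pair that isolates this position. Compound 4 gives > 100000 nM as a limit and not a number, so the step has no upper bound. Compound 1, with the free hydroxy, now stands alone with an actual number, and the rest of the series sits at the limit: the limit of > 100000 nM in this assay, at which 3 of the 4 values shown sit.

Going by these compounds, how an ethoxy or an amine in this place would read remains open. So does whether the step holds on a core other than that of compound 1.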